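The source may hold more compounds than are shown below. What is called first, only, known or untested is meant among the compounds shown, and "the series" means these compounds.

Measured in an ADME assay on RAW264.7 cells (Mus musculus) for cytotoxicity, read by MTT assay, with a stated time of 72 h, tested at 50 uM; a lower number here means a weaker effect, a higher number a stronger effect of the compound at the concentration tested:
compound 1 `O=C(Cn1c(=O)oc2cc(Cl)ccc21)NCc1cccs1` gives 20.3%;
compound 2 `O=C(Cn1c(=O)oc2cc(Cl)ccc21)NCc1ccco1` gives 27.8%;
compound 3 `O=C(Cn1c(=O)oc2cc([N+](=O)[O-])ccc21)NCc1ccco1` gives 26.8%.

Compound 4 `O=C(Cn1c(=O)oc2cc([N+](=O)[O-])ccc21)NCc1cccs1` has not yet been measured in this assay. It differs from compound 3 by thiophen-2-yl in place of furan-2-yl on a saturated chain carbon bound to an amide-type nitrogen. The same change occurs twice among these four compounds: once from compound 2 to compound 1, where it gave a number 7.5 percentage points lower from compound 2 to compound 1 (within the scatter), and once from compound 3 to compound 4. The cores of compound 2 and compound 3 differ by nitro in place of chloro on an aromatic carbon, a change that gave a number 1 percentage points lower from compound 2 to compound 3 (within the scatter). Since the place of the change is the same in both pairs, the step from compound 3 to compound 4 is expected to resemble the earlier one, and compound 4 is estimated to give a number 5.8 percentage points lower from compound 3 to compound 4 (within the scatter). Compound 4 is therefore expected to reach about 21%, most likely between 10% and 32%; this rests on the small earlier step of a number 7.5 percentage points lower from compound 2 to compound 1 (within the scatter) and on compound 3 at 26.8%.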

Compound 4, a percentage reported as inhibition, at one concentration (the size of the read-out at that concentration, not a potency): 36.6%
Compound 4: middle estimate off by 15.6 percentage points, on the low side; the measured number lies above the stated range.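

In this assay, with nitro on the core, thiophen-2-yl in place of furan-2-yl gave a number 9.8 percentage points higher from compound 3 to compound 4 (within the scatter), so this change did not carry over from the core bearing chloro: the same change on two cores in this assay, a number 7.5 percentage points lower (within the scatter) from compound 2 to compound 1 and a number 9.8 percentage points higher (within the scatter) from compound 3 to compound 4, 17.3 percentage points apart, beyond the scatter of two such steps. Nitro in place of chloro gave a number 16.3 percentage points higher from compound 1 to compound 4 (beyond the scatter), so it too depended on the other group present: the same change on two cores in this assay, a number 1 percentage points lower (within the scatter) from compound 2 to compound 3 and a number 16.3 percentage points higher (beyond the scatter) from compound 1 to compound 4, 17.3 percentage points apart, beyond the scatter of two such steps. This shows that the two changes do not add up independently in these four compounds, but it does not show why, nor whether the same holds on any other core.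

The compounds shown leave open how an amine or a nitrile would behave in place of chloro or nitro on the aromatic carbon. They also leave open whether a longer chain between the amide nitrogen and the thiophen-2-yl or furan-2-yl ring would behave the same way.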